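The compounds below may be only part of what the source reports. "The series", "measured", "known", "first", "only" and "open" are said of these compounds alone.

Of the compounds shown here, three sharing a core have been measured in a functional assay on MDA-MB-231 cells (Homo sapiens) for cytotoxicity, read by ELISA, with a stated time of 2 days; on this read-out lower numbers stand for stronger inhibition and higher numbers for weaker inhibition. Compound 1 `Oc1ccc(-c2cc(-c3ccccc3)cc(-c3ccco3)n2)cc1` gives 1400 nM, and compound 2 `Oc1ccc(-c2cc(-c3ccccc3)cc(-c3cccnc3)n2)cc1` gives 2200 nM. Compound 3 `Oc1cccc(-c2cc(-c3ccccc3)nc(-c3ccccc3)c2)c1` gives 19500 nM, the highest number of the three and beyond the scatter from both others. Compound 4 `Oc1cccc(-c2cc(-c3ccccc3)nc(-c3ccncc3)c2)c1` differs from compound 3 in one place, with pyridin-4-yl in place of phenyl on an aromatic carbon, next to the ring nitrogen (pyridin-4-yl in place of phenyl on an aromatic carbon).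

Going by the values given here, the only measured step that bears on this is a 1.6-fold higher number from compound 1 to compound 2 (0.20 log units; within the scatter), where pyridin-3-yl replaces furan-2-yl. It exchanges a different pair of groups, so it is only a loose guide, but it suggests that swapping one such ring for another need not move the number much. Compound 3 also stands beyond the scatter from compound 2, which gives 2200 nM, though those two differ elsewhere as well, which gives only a slight lean towards a lower number. The estimated step in this assay is a 1.8-fold lower number from compound 3 to compound 4 (0.25 log units; within the scatter), a size within the scatter. For compound 4 the expected value is 11000 nM, with an estimated range of 3500 nM to 30000 nM.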

Compound 4, half-maximal inhibitory concentration: 12200 nM
For compound 4 the middle estimate is 1.1-fold (0.04 log units) below the measured one; measured number inside the range.
By their numbers in this assay, from the lowest: compounds 1 and 2 (each within the scatter of the next); then compounds 4 and 3 (each within the scatter of the next).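

In this assay, putting pyridin-4-yl in place of phenyl on this aromatic carbon, next to the ring nitrogen, gives a 1.6-fold lower number from compound 3 to compound 4 (0.20 log units; within the scatter). Going by these compounds alone, this is the first one-place comparison at this position, and it shows that this exchange, which adds one hydrogen-bond acceptor to the group, produces no difference that can be told from the scatter. Nothing measured here offers an explanation for this outcome.

Still open, going by these compounds, is whether a group of a different kind at this position, such as an amine, a carboxylic acid or a longer alkyl chain, would move the number beyond the scatter. Also open, on these data alone, is whether pyridin-3-yl or furan-2-yl at this position would give a number close to those of compound 3 and compound 4.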